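Two hydrazones measured, a third awaited

A few compounds are considered here, and "the series" means these few. Any claim that something is new, unique, unknown or untested is made for them only; others in the source may bear on it.

In an ADME assay on MT4 cells (Homo sapiens) for cytotoxicity, read by MTT assay, with a stated time of 4 days (on this read-out higher numbers stand for lower toxicity in this test and lower numbers for higher toxicity in this test), the measured compounds are:
compound 1 `O=C(COc1cccc2ccccc12)N/N=C/c1ccc(O)cc1` — 26.5 ug/mL
compound 2 `O=C(COc1cccc2ccccc12)N/N=C/c1ccc(Br)cc1` — 106 ug/mL

Compound 2 stands as the higher of the two numbers. Compound 3 `O=C(COc1cccc2ccccc12)N/N=C/c1ccccc1O` differs from compound 2 in one place: 2-hydroxyphenyl in place of 4-bromophenyl on a carbon with a double bond to nitrogen. Among the compounds with values here, only one measured step bears on this change, a 4.0-fold higher number from compound 1 to compound 2 (0.60 log units; beyond the scatter), in which bromo replaced hydroxy; the new change reverses that exchange, though with the hydroxy carried as 2-hydroxyphenyl rather than 4-hydroxyphenyl. In this assay compound 3 is therefore expected to fall below compound 2 by a 3.0-fold lower number from compound 2 to compound 3 (0.48 log units; beyond the scatter). The estimate for compound 3 is 35 ug/mL, with a range from 15 ug/mL to 90 ug/mL.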

Compound 3, half-maximal cytotoxic concentration: 5.19 ug/mL
Estimate against measurement, compound 3: 6.7-fold (0.83 log units) above; the measured number lies below the stated range.
By their numbers in this assay, from the lowest: compound 3; then compound 1; then compound 2.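

In this assay the place of the hydroxy on the ring matters, not only its presence: with the hydroxy carried as 2-hydroxyphenyl rather than 4-hydroxyphenyl, the result is a 5.1-fold lower number from compound 1 to compound 3 (0.71 log units; beyond the scatter). Replacing 4-bromophenyl gives a larger change, a 20-fold lower number from compound 2 to compound 3 (1.31 log units; beyond the scatter), which leaves compound 3 with the lowest number of the three. Nothing measured here explains either step. On these data alone, whether a methoxy or an amine in the hydroxy's stead would give a similarly low number remains open.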